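Compound 3 After Compound 2: One Change, One Expectation

The source may hold more compounds than are shown below. What is called first, only, known or untested is meant among the compounds shown, and "the series" means these compounds.

Compound 1 `CCc1cc(Cl)c(S(C)(=O)=O)cc1C(=O)N=C(N)N`: 63 nM
Compound 2 `Cc1cc(-c2ccc(Cl)cc2Cl)c(S(C)(=O)=O)cc1C(=O)N=C(N)N`: 42 nM

In a functional assay for inhibition of sodium/hydrogen exchanger (Oryctolagus cuniculus) (a lower number here means a stronger inhibitor, a higher number a weaker inhibitor), compound 2 gives the lowest of the two numbers shown, though compound 1 sits within the scatter of it, so no order between the two can be claimed. Compound 3 `Cc1cc(OC2CCCCC2)c(S(C)(=O)=O)cc1C(=O)N=C(N)N` differs from compound 2 in one place: cyclohexyloxy in place of 2,4-dichlorophenyl on an aromatic carbon. Among the compounds with values here, no measured pair shows a change of this kind, so the data give no size for its effect. Compound 3 is expected to lie close to compound 2. The step of a 1.4-fold higher number from compound 2 to compound 3 (0.15 log units; within the scatter) is expected to fall within the scatter. In this assay compound 3 is estimated at 60 nM, within 20 nM to 200 nM.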

Compound 3, half-maximal inhibitory concentration: 37 nM
Compound 3: the middle estimate sits 1.6-fold (0.21 log units) above what was measured, within the range that was stated.
By their numbers in this assay, from the lowest: compounds 3, 2 and 1 (each within the scatter of the next).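

Cyclohexyloxy in place of 2,4-dichlorophenyl, on the aromatic carbon ortho to a methylsulfonyl group, gives a 1.1-fold lower number from compound 2 to compound 3 (0.06 log units; within the scatter) in this assay for this pair. At this position, then, a six-membered non-aromatic ring carried through oxygen and a six-membered aromatic ring of carbon only are not told apart by the read-out. Nothing at hand gives a reason for this match. Going by these compounds, whether an amine, a carboxylic acid or a plain methoxy on this same carbon would also leave the number in place stays open.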